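A benzyl swap on a compound at the limit

A few compounds are considered here, and "the series" means these few. Any claim that something is new, unique, unknown or untested is made for them only; others in the source may bear on it.

So far, two compounds sharing a core have been tested in a functional assay on SK-HEP1 cells (Homo sapiens) for inhibition, read by sulforhodamine B assay, with a stated time of 48 h; on this read-out lower numbers stand for stronger inhibition and higher numbers for weaker inhibition. Compound 1 (`O=C(Nc1ccc(Nc2ncc(C(=O)NO)cn2)cc1)Nc1ccc(Cl)c(C(F)(F)F)c1`) gives > 10000 nM in this test, which is a limit and not a number. Compound 2 (`O=C(CCCCCC(=O)Nc1ccc(NC(=O)Nc2ccc(Cl)c(C(F)(F)F)c2)cc1)NO`) gives > 10000 nM in this test, which is also a limit, so it has no readable position. The evidence so far is the limit of > 10000 nM in this assay, at which 2 of the 2 values shown sit, and nothing more. Within the data shown here, the one measured step is a step that the two limits leave unreadable from compound 1 to compound 2 and offers no size to carry forward.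

Compound 3 (`O=C(Nc1ccc(NCc2ccc(C(=O)NO)cc2)cc1)Nc1ccc(Cl)c(C(F)(F)F)c1`) carries 4-(hydroxycarbamoyl)benzyl in place of (5-(hydroxycarbamoyl)pentyl)carbonyl on a nitrogen on an aromatic ring. With no readable step to draw on, no change beyond the scatter is expected in this assay, and the estimated step is a number no higher from compound 2 to compound 3 (the limit leaves the size open) on that basis. For compound 3 the expected value is 10000 nM, with an estimated range from 3000 nM to 30000 nM.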

Compound 3, half-maximal inhibitory concentration: 7200 nM
Estimate against measurement, compound 3: 1.4-fold (0.14 log units) above; the range from low to high includes it.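

In this assay, compound 3 gives 7200 nM, the only actual number among the compounds shown, so swapping in 4-(hydroxycarbamoyl)benzyl on this nitrogen gives the position its first readable value. Against the other two compounds, the data give only an at least 1.3-fold lower number from compound 2 to compound 3 (0.14 log units; that floor lies within the scatter) and an at least 1.3-fold lower number from compound 1 to compound 3 (0.14 log units; that floor lies within the scatter); each is a floor within the usual scatter, so neither shows a real difference, though the true gaps could be larger. The step between compound 1 and compound 2 cannot be read, and the picture remains dominated by the assay limit: the limit of > 10000 nM in this assay, at which 2 of the 3 values shown sit.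

On these data alone, whether the aromatic ring of the 4-(hydroxycarbamoyl)benzyl group has any effect at all remains open. Also open, as far as these compounds go, is how compound 3 would read in this assay with a carboxylic acid in place of its hydroxycarbamoyl group.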